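Alkoxy chain growth on the pendant aryl: compound 3 to compound 4

The source may hold more compounds than are shown below. What is called first, only, known or untested is meant among the compounds shown, and "the series" means these compounds.

Among the compounds with values here, compound 3 `CCOc1cccc(F)c1-c1cccc2nc(Nc3cc(OC)c(OC)c(OC)c3)oc12` gives 490 nM in an assay on isolated protein for inhibition of ribosomal protein S6 kinase alpha-2 (Homo sapiens), with a stated time of 150 min (a higher number here means a weaker inhibitor, a lower number a stronger inhibitor), the highest of the three numbers so far; compound 1 `COc1cc(Nc2nc3cccc(-c4c(F)cccc4OC)c3o2)cc(OC)c1OC` gives 20 nM and compound 2 `COc1ccccc1-c1cccc2nc(Nc3cc(OC)c(OC)c(OC)c3)oc12` gives 20 nM. Compound 4 `COc1cc(Nc2nc3cccc(-c4c(F)cccc4OC(C)C)c3o2)cc(OC)c1OC` differs from compound 3 by methyl in place of hydrogen on a saturated chain carbon bound to an oxygen on an aromatic ring and a saturated chain carbon. The step that bears on this is a 25-fold higher number from compound 1 to compound 3 (1.39 log units; beyond the scatter), the same kind of chain growth at the same aryl oxygen; no change at the digits printed from compound 1 to compound 2 (within the scatter) concerns only the fluoro and says nothing about this change. The step from compound 3 to compound 4 is expected to run in the same direction, with the number rising again but probably by less than the first extension, so a 3.1-fold higher number from compound 3 to compound 4 (0.49 log units; beyond the scatter). Compound 4 is therefore estimated at 1500 nM, with a range of 400 nM to 6000 nM.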

Compound 4, half-maximal inhibitory concentration: 970 nM
Compound 4: the middle estimate sits 1.5-fold (0.19 log units) above what was measured; the measured number falls inside the stated range.
By their numbers in this assay, from the lowest: compounds 1 and 2 (each within the scatter of the next); then compounds 3 and 4 (each within the scatter of the next).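

In this assay, ethoxy to isopropoxy gives a 2.0-fold higher number from compound 3 to compound 4 (0.30 log units; within the scatter), so this branching adds nothing separable from the scatter, unlike the earlier methoxy to ethoxy step of a 25-fold higher number from compound 1 to compound 3 (1.39 log units; beyond the scatter). Isopropyl in place of methyl on the oxygen gives a 49-fold higher number from compound 1 to compound 4 (1.69 log units; beyond the scatter), and the comparison with the fluoro-free methoxy compound gives a 49-fold higher number from compound 2 to compound 4 (1.69 log units; beyond the scatter), so the large rise seen with ethoxy persists with isopropoxy.

From the compounds shown here alone, whether a hydroxyl or a longer chain on this aryl position would hold the number near that of compound 1 stays open. Nothing at hand gives a reason for these steps.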